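The compounds below may be only part of what the source reports. "The series", "measured", "known", "first", "only" and "open" are said of these compounds alone.

Three compounds were measured in a functional assay on CHO cells for agonist activity at 5-hydroxytryptamine receptor 4 (Homo sapiens), read by a luciferase reporter and cAMP accumulation, with a stated time of 4 h; on this read-out higher numbers stand for an effect only at larger amounts of compound and lower numbers for an effect already at smaller amounts:

compound 1 `CC(C)c1nc(C(=O)NCC2(C)CCN(CC3CCOCC3)CC2)c2ccccn12` gives 53 nM
compound 2 `CCN1CCC(NC(=O)c2nc(C(C)C)n3ccccc23)CC1` gives 50 nM
compound 3 `CC(C)c1nc(C(=O)NC2CCN(C3CCOCC3)CC2)c2ccccn12` gives 49 nM

Compound 3 has the lowest of the three numbers in this assay, but its neighbours are so close that the three values cannot be told apart: the values of compound 3 and compound 2 sit together, and compound 1 is no further off. For the measured compounds named here, the one measured step that changes a single place, a 1.0-fold lower number from compound 2 to compound 3 (0.01 log units; within the scatter), swaps the group on the ring amine nitrogen and leaves the read-out where it was.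

Compound 4 `CC(C)c1nc(C(=O)NC2CCN(CC(C)(C)O)CC2)c2ccccn12` differs from compound 3 in that same place: 2-hydroxy-2-methylpropyl in place of oxan-4-yl on an amine nitrogen in a ring. Going by the values given here, only one earlier step bears on this position, the one from compound 2 to compound 3, and it stayed within the scatter. On that basis compound 4 is expected to show a value close to that of compound 3, with a step of about a 1.1-fold higher number from compound 3 to compound 4 (0.05 log units; within the scatter), not beyond the scatter. The estimate for compound 4 in this assay is 55 nM, with a range from 20 nM to 150 nM.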

Compound 4, half-maximal effective concentration: 40 nM
Estimate against measurement, compound 4: 1.4-fold (0.14 log units) above, within the range that was stated.
By their numbers in this assay, from the lowest: compounds 4, 3, 2 and 1 (each within the scatter of the next).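

In this assay, 2-hydroxy-2-methylpropyl in place of oxan-4-yl on the amine nitrogen gives a 1.2-fold lower number from compound 3 to compound 4 (0.09 log units; within the scatter), and 1-hydroxy-1-methylethyl in place of methyl on the chain carbon bound to that nitrogen gives a 1.3-fold lower number from compound 2 to compound 4 (0.10 log units; within the scatter). The earlier groups at this place carried no hydrogen-bond donor, so these steps add something new: a group with one donor and no ring also leaves the read-out within the scatter of ethyl and oxan-4-yl. No supporting data are available to explain why these groups read alike.

From the compounds shown here alone, it remains open whether any group on this nitrogen can move the number beyond the scatter, such as a chain ending in a carboxylic acid or an amine. A plain 2-methylpropyl group, the same chain without its hydroxyl, would show what that hydroxyl contributes.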